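Adding a methyl to the amine of compound 1

The source may hold more compounds than are shown below. What is called first, only, known or untested is meant among the compounds shown, and "the series" means these compounds.

Compound 1 `COc1cc2c(cc1C(C)NCCCc1ccccc1)C=CC(C)(C)O2` carries a free amine hydrogen on the chain that joins its core to a phenethyl group. In an assay on cell membranes for displacement of a labelled ligand from Sigma non-opioid intracellular receptor 1 (Cavia porcellus), read by scintillation counting (on this read-out lower numbers stand for stronger inhibition and higher numbers for weaker inhibition), compound 1 gives 11 nM, the lowest of the three numbers shown. Compound 3 `CCCCNC(C)c1cc2c(cc1OC)OC(C)(C)C=C2` gives 22 nM in this assay, and a 2.0-fold higher number from compound 1 to compound 3 (0.30 log units; within the scatter). Compound 2 `COc1ccc(CNC(C)c2cc3c(cc2OC)OC(C)(C)C=C3)cc1` gives 165 nM in this assay, and a 15-fold higher number from compound 1 to compound 2 (1.18 log units; beyond the scatter), while a 7.5-fold lower number from compound 2 to compound 3 (0.88 log units; beyond the scatter). All three of these steps change what hangs on the chain carbon or at the end of the chain, and none of them touches the amine nitrogen itself.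

Compound 4 `COc1cc2c(cc1C(C)N(C)CCCc1ccccc1)C=CC(C)(C)O2` differs from compound 1 by one change: methyl in place of hydrogen on an amine nitrogen. Among the measured compounds shown here, no measured step speaks directly to this change, so the expectation rests on the fact that the rest of compound 4 is unchanged from compound 1, whose value is 11 nM. The step is therefore expected to stay within the scatter, with no direction favoured; the estimate for a 1.4-fold higher number from compound 1 to compound 4 (0.13 log units; within the scatter) reflects that. Compound 4 is accordingly estimated at 15 nM in this assay, with a range from 4 nM to 55 nM.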

Compound 4, inhibition constant: 0.95 nM
The estimate for compound 4 lay 16-fold (1.20 log units) above the measured number; the measured number lies below the stated range.
By their numbers in this assay, from the lowest: compound 4; then compounds 1 and 3 (each within the scatter of the next); then compound 2.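

The amine nitrogen of compound 1 turns out to be a sensitive place: in this assay, methyl in place of hydrogen, a change of a single heavy atom, gives a 12-fold lower number from compound 1 to compound 4 (1.06 log units; beyond the scatter), which is beyond the scatter and counts as large. Among the compounds shown here, the earlier changes all lay on the chain and none took the number below that of compound 1, although one of them, a 15-fold higher number from compound 1 to compound 2 (1.18 log units; beyond the scatter), was also large, so compound 4 is the first compound here to show a clear gain over compound 1, and it does so with the smallest change of the set. Nothing measured here explains why this methyl has such an effect, so the step stands as an observation without a known cause.

The compounds shown leave open whether an ethyl or a longer chain on the same nitrogen would extend this gain or reverse it. They also leave open whether methyl on the amine nitrogen of compound 2 or compound 3 would give a step of similar size, so the result so far holds only for the phenethyl compound.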